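Adding one methoxy group to compound 2

The compounds below may be only part of what the source reports. "The series", "measured", "known", "first", "only" and "open" are said of these compounds alone.

Measured in a functional assay on HepG2 cells (Homo sapiens) for inhibition, read by MTT assay, with a stated time of 48 h; a higher number here means a weaker inhibitor, a lower number a stronger inhibitor:
Compound 1 `COc1ccc(C(=O)C=CNc2cc(-c3ccccc3)nn2-c2ccccc2)cc1` gives 2030 nM
Compound 2 `c1ccc(-c2ccnc3c2c(-c2ccccc2)nn3-c2ccccc2)cc1` gives 3210 nM
Compound 3 `N#Cc1c(-c2ccc(Cl)cc2)nc2c(c(-c3ccccc3)nn2-c2ccccc2)c1-c1ccc(N2CCCCC2)cc1` gives 3210 nM

Compound 2 matches compound 3, and compound 1 lies within the usual scatter of both. Compound 4 `COc1ccc(-c2ccnc3c2c(-c2ccccc2)nn3-c2ccccc2)cc1` differs from compound 2 by a single change methoxy in place of hydrogen on an aromatic carbon with methoxy in place of hydrogen on an aromatic carbon, para to a large group, turning phenyl into 4-methoxyphenyl. Within the data shown here, no measured pair tests this change. Compound 1 also carries a methoxy group and gives 2030 nM but differs from compound 2 in much more. Among the measured compounds shown here, the expected step of a 1.3-fold lower number from compound 2 to compound 4 (0.11 log units; within the scatter) is slightly downward and within the scatter in this assay as the only guide. Estimated for compound 4: 2500 nM with 900 nM to 7000 nM as the expected range.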

Compound 4, half-maximal inhibitory concentration: 6590 nM
The estimate for compound 4 lay 2.6-fold (0.42 log units) below the measured number, within the range that was stated.
By their numbers in this assay, from the lowest: compounds 1, 2 and 3 (each within the scatter of the next); then compound 4.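

Among these compounds, this is the first direct test of the change: in this assay, methoxy in place of hydrogen, para to a large group, gives a 2.1-fold higher number from compound 2 to compound 4 (0.31 log units; beyond the scatter) and so a weaker inhibitor, though the step is modest. Compound 1 also carries a methoxy group but differs from compound 2 in much more, and could not show this. Nothing shown explains the step.

As far as these compounds go, whether a hydroxyl group, a fluorine atom or an amine at this same place would also weaken inhibition stays open. So does whether a longer chain in place of methoxy would move the number further.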